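The source may hold more compounds than are shown below. What is called first, only, known or untested is meant among the compounds shown, and "the series" means these compounds.

Measured so far in a functional assay on MDA-MB-468 cells (Homo sapiens) for antiproliferative activity, read by sulforhodamine B assay, with a stated time of 72 h; a lower number here means a stronger inhibitor, a higher number a weaker inhibitor:
- compound 1 `FC(F)(F)c1ccc(/C=C\c2cc3ccccc3nc2Cl)cc1` gives 7380 nM
- compound 2 `Fc1ccc(/C=C\c2cc3ccc(Cl)cc3nc2Cl)cc1` gives 10900 nM
- compound 3 `COc1ccc2nc(Cl)c(/C=C\c3ccc(C(F)(F)F)cc3)cc2c1` gives 22700 nM

Compound 3 has the highest number of the three. Compound 4 `COc1ccc2nc(Cl)c(/C=C/c3ccc(C(F)(F)F)cc3)cc2c1` departs from it in one respect only: the two compounds have the same atoms and bonds and differ only in configuration as drawn: 1 of 1 stereo elements differ; a double bond is drawn Z in compound 3 and E in compound 4 and a double bond is drawn Z in compound 3 and E in compound 4. Within the data shown here, the one measured step is methoxy in place of hydrogen on an aromatic carbon, with a 3.1-fold higher number from compound 1 to compound 3 (0.49 log units; beyond the scatter) as its modest size, and it does not bear on configuration. Among the measured compounds shown here, all three measured compounds are drawn Z, so no measured pair tests this change. No step beyond the scatter is therefore expected in this assay, and no direction can be argued. The expected change is a 1.1-fold lower number from compound 3 to compound 4 (0.05 log units; within the scatter) and is quite uncertain. Compound 4 is estimated at 20000 nM with 6000 nM to 60000 nM as the expected range.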

Compound 4, half-maximal inhibitory concentration: > 50000 nM
Compound 4 gave a limit, no number (the forecaster's own chance of this, stated with the estimate: 15%); middle value at least 2.5-fold (0.39 log units) from the limit.
By their numbers in this assay, from the lowest: compounds 1 and 2 (each within the scatter of the next); then compound 3. At a limit, above all of these: compound 4.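

In this assay, among these compounds, the Z to E change on the double bond is the first change of configuration read, and it moves the number upward (an at least 2.2-fold higher number from compound 3 to compound 4 (0.34 log units; beyond the scatter)). Compound 4 gives > 50000 nM and that is a limit, not a number. The step can be put on configuration alone because of one fact: (the fact that compounds 3 and 4 differ only in the configuration as drawn).

On these data alone, whether the same Z to E change holds for the substituent patterns of compound 1 and compound 2 stays open. Also open, as far as these compounds go, is how an amine or a carboxylic acid in place of the trifluoromethyl group would read.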